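The source may report more compounds than this note shows. Statements on the series, on what has been measured and on what is new or still open speak of the compounds shown alone.

Compound 1 `O=S(=O)(Nc1ccccc1)c1ccccc1` is the parent of a small set sharing one core, and in an ADME assay, compound 1 gives 9.1. Compound 2 `O=S(=O)(Nc1ccc(Cl)cc1)c1ccccc1` gives 8.75, and compound 3 `O=S(=O)(Nc1ccc(F)cc1)c1ccccc1` gives 8.85, so compound 3 stands second highest of the three, within the scatter of both others: a number 0.10 log units higher from compound 2 to compound 3 (within the scatter) and a number 0.25 log units lower from compound 1 to compound 3 (within the scatter). Compound 4 `O=S(=O)(Nc1ccc(F)cc1)c1ccc(Cl)cc1` differs from compound 3 by chloro in place of hydrogen on an aromatic carbon, sitting on an aromatic carbon of a six-membered aromatic ring of carbon only, para to a large group. The measured step that matches this swap is a number 0.35 log units lower from compound 1 to compound 2 (beyond the scatter), which lowered the number beyond the scatter, whereas a number 0.25 log units lower from compound 1 to compound 3 (within the scatter) stayed within it. A lowering of comparable size is therefore expected, a number 0.40 log units lower from compound 3 to compound 4 (beyond the scatter). Compound 4 is expected to give about 8.45, between 8.15 and 8.75.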

Compound 4, acid dissociation constant: 8.41
Beside the measured number, compound 4's estimate is 0.04 log units above it; the measured number falls inside the stated range.
By their numbers in this assay, from the lowest: compound 4; then compounds 2, 3 and 1 (each within the scatter of the next, the first and the last beyond it).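

In this assay, chloro in place of hydrogen on an aromatic carbon para to a large group gives a number 0.44 log units lower from compound 3 to compound 4 (beyond the scatter). Until now this swap had been seen only once, and compound 4 shows it lowering the number again on a second core, one that already carries fluoro. The two steps agree closely: the same change on two cores in this assay, a number 0.35 log units lower (beyond the scatter) from compound 1 to compound 2 and a number 0.44 log units lower (beyond the scatter) from compound 3 to compound 4, 0.09 log units apart, within the scatter of two such steps

The compounds shown leave open whether a different group at this position, such as an amine, a carboxylic acid or a longer chain, would lower the number as well or raise it instead.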